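The source may hold more compounds than are shown below. What is called first, only, known or untested is meant among the compounds shown, and "the series" means these compounds.

Compound 1, `CCc1cc(S(=O)(=O)N2C[C@H](c3ccccc3)NC2=O)ccc1NC(=O)c1ccc(N)cc1`: 670 nM
Compound 2, `CCc1cc(S(=O)(=O)N2C[C@H](c3ccccc3)NC2=O)ccc1NC(=O)NC(C)C`: 70 nM

In a functional assay on NCI-H460 cells (Homo sapiens) for cytotoxicity, read by MTT assay (a lower number here means a stronger inhibitor, a higher number a weaker inhibitor), compound 2 gives the lowest of the two numbers; its nearest neighbour is compound 1, whose value lies higher by a 9.6-fold lower number from compound 1 to compound 2 (0.98 log units; beyond the scatter). Compound 3, `CCOC(=O)Nc1ccc(S(=O)(=O)N2C[C@H](c3ccccc3)NC2=O)cc1CC`, has not yet been measured. It differs from compound 2 at one point: ethoxy in place of isopropylamino on a carbonyl carbon. Among the compounds with values here, only one measured step touches the same carbonyl carbon, the change from compound 1 to compound 2, which gave a 9.6-fold lower number from compound 1 to compound 2 (0.98 log units; beyond the scatter) when isopropylamino replaced 4-aminophenyl. Within the data shown here, that step swapped one kind of substituent for another on the same carbon, but neither of its two groups is ethoxy, so it offers no direct precedent for the present exchange. With a single pair to go on, the size of the coming step is uncertain; a shift within the scatter or a modest rise in this assay seems the more likely outcome, and the estimate for compound 3 is set at 150 nM, within 50 nM to 450 nM, corresponding to an expected step of a 2.1-fold higher number from compound 2 to compound 3 (0.33 log units; beyond the scatter).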

Compound 3, half-maximal inhibitory concentration: 70 nM
Estimate against measurement, compound 3: 2.1-fold (0.33 log units) above; the measured number falls inside the stated range.
By their numbers in this assay, from the lowest: compounds 2 and 3 (each within the scatter of the next); then compound 1.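

In this assay, replacing isopropylamino (1 hydrogen-bond donor, 0 hydrogen-bond acceptors) with ethoxy (0 hydrogen-bond donors, 1 hydrogen-bond acceptor) on a carbonyl carbon gives no change at the digits printed from compound 2 to compound 3 (within the scatter), so this position tolerates this particular exchange without any reading beyond the scatter. Ethoxy in place of 4-aminophenyl gives a 9.6-fold lower number from compound 1 to compound 3 (0.98 log units; beyond the scatter), a step that matches a 9.6-fold lower number from compound 1 to compound 2 (0.98 log units; beyond the scatter), so among these three compounds it is compound 1, with 4-aminophenyl, that stands apart, while the two groups with no ring give values within the scatter of each other. No independent data accompany these numbers to explain why the two groups read alike here.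

From the compounds shown here alone, whether the match extends to other groups on this carbonyl carbon remains open, for instance a longer chain such as n-butoxy, a dimethylamino group or an unsubstituted phenyl, any of which could show whether the low number belongs to a wider set of groups or only to these two. Going by these compounds, it also remains open whether compound 2 and compound 3 would stay level in cell lines other than the one used in this assay.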